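A few compounds are considered here, and "the series" means these few. Any claim that something is new, unique, unknown or untested is made for them only; others in the source may bear on it.

In a functional assay on HCT-116 cells (Homo sapiens) for antiproliferative activity, read by MTT assay, with a stated time of 48 h (a lower number here means a stronger inhibitor, a higher number a weaker inhibitor), compound 1 `COc1ccc(CN(C(=O)CSc2nc3ccccc3s2)c2cc(OC)c(OC)c(OC)c2)cc1Br` gives 4550 nM. Compound 2 `COc1ccc(CN(C(=O)CSc2nc3ccccc3s2)c2cc(OC)c(OC)c(OC)c2)cc1C(F)(F)F` carries trifluoromethyl on the aromatic carbon where compound 1 has bromo. Compound 2 stands at > 80000 nM, which is a limit of the assay and not a number. It therefore has no exact place on the scale, and (the limit of > 80000 nM in this assay, at which 1 of the 2 values shown sits). Compound 3 `COc1ccc(CN(C(=O)CSc2nc3ccccc3s2)c2cc(OC)c(OC)c(OC)c2)cc1N` changes that same aromatic carbon, and its difference from compound 2 reads (amino in place of trifluoromethyl on an aromatic carbon). The 4-methoxy-3-(trifluoromethyl)phenyl thus becomes 3-amino-4-methoxyphenyl.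

Going by the values given here, only one measured step bears on this place: an at least 17-fold higher number from compound 1 to compound 2 (1.24 log units; beyond the scatter). It is large and beyond the scatter, so the group on this carbon clearly matters in these two compounds. Among the compounds with values here, no amino compound has yet been measured, so the size of the next step is uncertain. Within the data shown here, the expectation leans towards compound 1 at 4550 nM, the only number measured with a group at this place. The expected change is an at least 10-fold lower number from compound 2 to compound 3 (1.00 log units; beyond the scatter), a large step to a lower number. For compound 3 the estimate is 8000 nM, with an expected range from 1000 nM to 50000 nM.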

Compound 3, half-maximal inhibitory concentration: 491 nM
For compound 3 the middle estimate is 16-fold (1.21 log units) above the measured one, outside the stated range (below it).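

In this assay this aromatic carbon now has three groups to compare, and the change from bromo to amino is a step between two real numbers: there is a 9.3-fold lower number from compound 1 to compound 3 (0.97 log units; beyond the scatter) and it is modest in size. The change from trifluoromethyl is much larger, with an at least 160-fold lower number from compound 2 to compound 3 (2.21 log units; beyond the scatter) in the same assay, so the group at this place can move the number in either direction from bromo, not only towards a weaker compound. Compound 2 carries a limit of the assay and not a number, so this larger step has only a bound and its true size cannot be read: the limit of > 80000 nM in this assay, at which 1 of the 3 values shown sits.

The compounds shown leave open whether the lower number belongs to the amino group alone or would also appear with a hydroxyl, a methylamino or an acetamido group on the same carbon. They also leave open whether the step from bromo to amino would hold on a different core or with a different group in place of the methoxy group.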